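Pentyl urea replacing pivalamide on a sulfonate ester scaffold

A few compounds are considered here, and "the series" means these few. Any claim that something is new, unique, unknown or untested is made for them only; others in the source may bear on it.

Compound 1 `CC(=O)Nc1ccc(S(=O)(=O)Oc2ccccc2I)cc1`: 27000 nM
Compound 2 `CC(C)c1ccccc1OS(=O)(=O)c1ccc(NC(=O)C(C)(C)C)cc1`: 6200 nM
Compound 3 `CC(C)(C)C(=O)Nc1ccc(S(=O)(=O)Oc2ccccc2I)cc1`: 8300 nM

In a functional assay on M21 cells (Homo sapiens) for antiproliferative activity, read by sulforhodamine B assay, with a stated time of 48 h (a lower number here means a stronger inhibitor, a higher number a weaker inhibitor), compound 2 gives the lowest of the three numbers, but its gap to compound 3 is within the scatter, and only its gap to compound 1 is beyond it. Compound 4 `CCCCCNC(=O)Nc1ccc(S(=O)(=O)Oc2ccccc2C(C)C)cc1` differs from compound 2 by pentylamino in place of tert-butyl on a carbonyl carbon. Within the data shown here, the one measured step that touches the carbonyl substituent is a 3.3-fold lower number from compound 1 to compound 3 (0.51 log units; beyond the scatter), a modest shift on a change of a different kind. The step of a 1.3-fold higher number from compound 2 to compound 3 (0.13 log units; within the scatter) concerns the other ring and does not bear here. No measured pair shows a carbonyl carbon bearing an amino group, so the urea of compound 4 has no precedent among these compounds, and the author expects at most a modest step in this assay, more likely toward a higher number than a lower one. Compound 4 is therefore estimated at 9000 nM, within 2500 nM to 30000 nM, which would mean an expected step of a 1.5-fold higher number from compound 2 to compound 4 (0.16 log units; within the scatter).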

Compound 4, half-maximal inhibitory concentration: 4600 nM
Compound 4: middle estimate off by 2.0-fold (0.29 log units), on the high side, within the range that was stated.
By their numbers in this assay, from the lowest: compounds 4, 2 and 3 (each within the scatter of the next); then compound 1.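

In this assay the swap of tert-butyl for pentylamino on a carbonyl carbon gives a 1.3-fold lower number from compound 2 to compound 4 (0.13 log units; within the scatter) and so brings no shift that stands clear of the scatter. The earlier compounds shown here showed only a 3.3-fold lower number from compound 1 to compound 3 (0.51 log units; beyond the scatter) at this carbonyl substituent, where a carbon group replaced a carbon group; compound 4 adds an amino-bearing substituent, with its longer chain and one hydrogen-bond donor, and the number stays level with that of compound 2. No measured evidence shown here speaks to the reason for this result.

From the compounds shown here alone, whether a shorter chain such as propylamino, or a cyclic amine such as piperidine, on this carbonyl carbon would move the number beyond the scatter remains open. So does whether pentylamino would give a similar result with the iodo group of compound 3 in place of isopropyl.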